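Phenyl for 2-Hydroxy-2-methylpropyl: Cytotoxicity Expectation

This account rests on a few compounds, and the source may have more. Where it says the series, first, only, none or still open, it means among the compounds named here.

Compound 1 `Cc1ccc2nc(-c3ccccn3)c(Nc3ccc4c(c3)OCCO4)n2c1` — 16000 nM
Compound 2 `Clc1ccc2nc(-c3ccccn3)c(Nc3ccc4c(c3)OCCO4)n2c1` — > 50000 nM
Compound 3 `CC(C)(O)CNc1c(-c2ccccn2)nc2ccccn12` — > 50000 nM

In an ADME assay on THP-1 cells (Homo sapiens) for cytotoxicity (on this read-out higher numbers stand for lower toxicity in this test and lower numbers for higher toxicity in this test), compound 1 gives 16000 nM. For compound 2 the result > 50000 nM is a limit of this assay, not a number. Compound 3 likewise stands at a limit, > 50000 nM, and (the limit of > 50000 nM in this assay, at which 2 of the 3 values shown sit).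

Compound 4 `c1ccc(Nc2c(-c3ccccn3)nc3ccccn23)cc1` differs from compound 3 in one place: phenyl in place of 2-hydroxy-2-methylpropyl on a nitrogen on an aromatic ring. Among the compounds with values here, the only measured step, an at least 3.1-fold higher number from compound 1 to compound 2 (0.49 log units; beyond the scatter), concerns a chloro for a methyl on an aromatic carbon elsewhere on the shared core, and so it does not bear on the change from compound 3 to compound 4; no measured pair shows an exchange at this nitrogen.

The expectation therefore rests on where compound 3 itself stands. The step of an at least 1.2-fold lower number from compound 3 to compound 4 (0.09 log units; that floor lies within the scatter) is expected to stay within the scatter, with no clear direction. Compound 4 is estimated at 40000 nM, with a range from 10000 nM to 120000 nM, and a real chance that only a limit is reported again.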

Compound 4, half-maximal cytotoxic concentration: 6690 nM
The estimate for compound 4 lay 6.0-fold (0.78 log units) above the measured number; measured number outside the range, below it.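

The exchange of 2-hydroxy-2-methylpropyl for phenyl on this nitrogen gives an at least 7.4-fold lower number from compound 3 to compound 4 (0.87 log units; beyond the scatter) in this assay, the only change at this position among the compounds shown, and it points toward higher toxicity in this test. The earlier chloro-for-methyl step lay elsewhere on the shared core, whereas this step shows that the group on this nitrogen alone can bring the read-out off the limit. Compound 3 stands at a limit of the assay, so the step gives only a floor and its full size stays unknown: the limit of > 50000 nM in this assay, at which 2 of the 4 values shown sit.

The change removes a hydroxy-bearing chain and brings in an aromatic ring in one move, so the compounds shown do not tell which of the two carries the step. A plain 2-methylpropyl chain or a cyclohexyl group on this nitrogen would separate them.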